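Swapping the Aryl Amine Substituent in a Lipoxygenase Series

The compounds below may be only part of what the source reports. "The series", "measured", "known", "first", "only" and "open" are said of these compounds alone.

compound 1 `Cc1cccc(Nc2cc(Cl)nc(SC(C(=O)O)c3ccccc3)n2)c1C` — "not active" (no number reported)
compound 2 `CCOC(=O)C(Sc1nc(Cl)cc(Nc2cccc(C)c2C)n1)c1ccccc1` — 53.1%
compound 3 `CCCCCCC(Sc1nc(Cl)cc(Nc2cccc(C)c2C)n1)C(=O)OCC` — 84.9%
compound 4 `CCOC(=O)C(Sc1nc(Cl)cc(Nc2ccc3ncccc3c2)n1)c1ccccc1` — not yet measured

In an assay for inhibition of Polyunsaturated fatty acid 5-lipoxygenase (Homo sapiens), tested at 1 uM (a lower number here means a stronger effect, a higher number a weaker effect of the compound at the concentration tested), compound 2 gives 53.1%, the lowest of the two numbers reported, while compound 3 gives 84.9% and compound 1 is recorded as "not active" (no number reported). Within the data shown here, the only measured step, a number 31.8 percentage points higher from compound 2 to compound 3 (beyond the scatter), concerns the saturated chain carbon and not the aryl amine. Compound 4 differs from compound 2 by quinolin-6-yl in place of 2,3-dimethylphenyl on a nitrogen on an aromatic ring. Among the measured compounds shown here, no measured step touches that position, so nothing measured bears directly on this change. The expected step is a number 6.9 percentage points higher from compound 2 to compound 4 (within the scatter), small and not clearly beyond the scatter, held with low confidence. Compound 4 is therefore estimated at 60%, with a range from 30% to 95%.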

Compound 4, a percentage reported as activity, at one concentration (the size of the read-out at that concentration, not a potency): 52.7%
Estimate against measurement, compound 4: 7.3 percentage points above; measured number inside the range.
By their numbers in this assay, from the lowest: compounds 4 and 2 (each within the scatter of the next); then compound 3.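

In this assay, among these compounds, the first reading at this position is a number 0.4 percentage points lower from compound 2 to compound 4 (within the scatter) for quinolin-6-yl in place of 2,3-dimethylphenyl on a nitrogen on an aromatic ring. An aryl group carrying a ring nitrogen and a second six-membered ring therefore reads alike with the carbon-only aryl group when the ethyl ester and phenyl are held constant. Nothing available explains this likeness. On these data alone, whether a cyclohexyl group or a pyridine ring on that nitrogen would also read alike remains open. So does whether quinolin-6-yl would behave the same way alongside the hexyl chain of compound 3.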